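The source may hold more compounds than are shown below. What is called first, only, known or untested is meant among the compounds shown, and "the series" means these compounds.

Measured compounds:
- compound 1, `FC(F)(F)Sc1ccc(-c2cc(CN(c3ncccn3)c3nc4ccccc4s3)on2)cc1`: 17200 nM
- compound 2, `FC(F)(F)Oc1ccc(-c2cc(CN(c3ncccn3)c3nc4ccccc4s3)on2)cc1`: 14800 nM

In a functional assay on MCF7 cells (Homo sapiens) for antiproliferative activity, read by MTT assay (on this read-out higher numbers stand for weaker inhibition and lower numbers for stronger inhibition), compound 1 gives 17200 nM and compound 2 gives 14800 nM; the two numbers sit within the scatter of each other, so neither compound can be called the stronger. Going by the values given here, the only measured step, a 1.2-fold lower number from compound 1 to compound 2 (0.07 log units; within the scatter), swaps one fluorinated group for another on the aromatic ring and shifts nothing beyond the scatter.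

Compound 3, `COc1ccc(-c2cc(CN(c3ncccn3)c3nc4ccccc4s3)on2)cc1`, differs from compound 2 by methyl in place of trifluoromethyl on an oxygen on an aromatic ring. Among the compounds with values here, no measured step follows this exact change. Within the data shown here, the one step that bears on it at all, a 1.2-fold lower number from compound 1 to compound 2 (0.07 log units; within the scatter), shows that altering the substituent on this aromatic ring left this assay unchanged, so a step of no more than the scatter is expected here, with no clear direction. Compound 3 is therefore estimated at 15000 nM, between 6000 nM and 40000 nM, meaning an expected step of a 1.0-fold higher number from compound 2 to compound 3 (0.01 log units; within the scatter).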

Compound 3, half-maximal inhibitory concentration: 30700 nM
Estimate against measurement, compound 3: 2.0-fold (0.31 log units) below; low and high end bracket the measured number.
By their numbers in this assay, from the lowest: compounds 2, 1 and 3 (each within the scatter of the next, the first and the last beyond it).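

In this assay, going by these compounds alone, the group on the oxygen does matter: methyl in place of trifluoromethyl gives a 2.1-fold higher number from compound 2 to compound 3 (0.32 log units; beyond the scatter) and so produces the first modest change that stands clear of the scatter, which the swap between the two fluorinated groups did not. Methoxy in place of (trifluoromethyl)sulfanyl gives a 1.8-fold higher number from compound 1 to compound 3 (0.25 log units; within the scatter) and stays within the scatter, so only the trifluoromethoxy to methoxy pair separates clearly. No measurement here offers an explanation for this difference.

On these data alone, whether a longer chain on the oxygen, such as ethyl, would behave more like methyl or like trifluoromethyl remains open. So does the outcome of putting an amine or a carboxylic acid on the aromatic ring instead, since all three compounds share the same core and differ only in this one substituent.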